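Benzyl Replaces Cyclopropyl on the Sulfonamide Nitrogen

The source may report more compounds than this note shows. Statements on the series, on what has been measured and on what is new or still open speak of the compounds shown alone.

Compound 1 `CC(C)CC1n2cncc2CN(C2CC2)S1(=O)=O` is the weakest of the three measured compounds in an assay on cells for inhibition of cytochrome P450 11B1, mitochondrial (Homo sapiens) (on this read-out higher numbers stand for weaker inhibition and lower numbers for stronger inhibition), where compound 1 gives 930 nM. Compound 3 `CC(C)CC1n2cncc2CN([C@@H](C)c2ccc(Cl)cc2)S1(=O)=O` carries a chlorophenyl-bearing group on the same nitrogen and gives 76 nM in this assay, and compound 2 `COC(C)(C)CC1n2cncc2CN([C@@H](C)c2ccc(Cl)cc2)S1(=O)=O` adds a methoxy on the isobutyl chain and gives 20.6 nM. Among the compounds with values here, the one measured step, a 3.7-fold higher number from compound 2 to compound 3 (0.57 log units; beyond the scatter), concerns the chain and not the sulfonamide nitrogen, so it does not bear directly on the change at hand. Compound 4 `CC(C)CC1n2cncc2CN(Cc2ccccc2)S1(=O)=O` differs from compound 1 by benzyl in place of cyclopropyl on a sulfonamide nitrogen in a ring. Within the data shown here, no step among the measured compounds describes this exact exchange; the values of compound 1 and compound 3 only show that an aryl-bearing group on this nitrogen went with a lower number than cyclopropyl. Compound 4 is therefore expected to show a lower number than compound 1, a 4.2-fold lower number from compound 1 to compound 4 (0.63 log units; beyond the scatter), though its benzyl lacks the methyl and chlorine of compound 3. The estimate for compound 4 is 220 nM, within 60 nM to 700 nM.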

Compound 4, half-maximal inhibitory concentration: 103 nM
For compound 4 the middle estimate is 2.1-fold (0.33 log units) above the measured one; the range from low to high includes it.
By their numbers in this assay, from the lowest: compound 2; then compounds 3 and 4 (each within the scatter of the next); then compound 1.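

In this assay benzyl in place of cyclopropyl on the sulfonamide nitrogen in a ring gives a 9.0-fold lower number from compound 1 to compound 4 (0.96 log units; beyond the scatter) with the isobutyl group and the rest of the core held constant, so the change at this position can now be read on its own. The earlier compounds shown here did not allow this, since the group on this nitrogen in compound 3 also carries a methyl and a chlorine, whereas the plain benzyl of compound 4 has neither and still gives a step beyond the scatter. No measured evidence bearing on the cause of this step is available.

The compounds shown leave open what a methyl or a chlorine contributes separately when added to the benzyl of compound 4. They also leave open how a longer chain on this nitrogen, or an amine or a carboxylic acid on the benzyl group, would change the number.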